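This account rests on a few compounds, and the source may have more. Where it says the series, first, only, none or still open, it means among the compounds named here.

Of the compounds shown here, three with a shared core have values so far in a functional assay on L1210 cells (Mus musculus) for inhibition; on this read-out higher numbers stand for weaker inhibition and lower numbers for stronger inhibition. Compound 1 `O=C1CCCCC/C1=C\c1ccccc1` gives 261000 nM in this test, compound 2 `O=C1CCCCC/C1=C\c1ccc(Cl)cc1` gives 83000 nM there, and compound 3 `COc1ccc(/C=C2\CCCCCC2=O)cc1` gives 306000 nM on the same scale. Compound 3 therefore sits level with compound 1 within the usual scatter, and compound 2 alone stands apart with a lower number.

Compound 4 `CN(C)c1ccc(/C=C2\CCCCCC2=O)cc1` has not been measured yet. Among the measured compounds shown here, it carries dimethylamino in place of methoxy on an aromatic carbon and no measured step makes this exact swap. Chloro in place of hydrogen gave a modest shift (a 3.1-fold lower number from compound 1 to compound 2 (0.50 log units; beyond the scatter)), and methoxy in place of chloro gave a modest shift back (a 3.7-fold higher number from compound 2 to compound 3 (0.57 log units; beyond the scatter)). Methoxy in place of hydrogen stayed within the scatter (a 1.2-fold higher number from compound 1 to compound 3 (0.07 log units; within the scatter)). For the measured compounds named here, only steps involving chloro have moved the number so far, and this swap involves no chloro. A step beyond the scatter is therefore not expected in this assay, and the estimated step is small (a 1.3-fold lower number from compound 3 to compound 4 (0.12 log units; within the scatter)). Compound 4 is estimated at 230000 nM (expected range 90000 nM to 500000 nM).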

Compound 4, half-maximal inhibitory concentration: 79100 nM
Compound 4: the middle estimate sits 2.9-fold (0.46 log units) above what was measured, and the stated range ends above it.
By their numbers in this assay, from the lowest: compounds 4 and 2 (each within the scatter of the next); then compounds 1 and 3 (each within the scatter of the next).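

In this assay, this position on the aromatic ring can respond to a change that involves no chloro: dimethylamino in place of methoxy gives a 3.9-fold lower number from compound 3 to compound 4 (0.59 log units; beyond the scatter), and dimethylamino in place of hydrogen gives a 3.3-fold lower number from compound 1 to compound 4 (0.52 log units; beyond the scatter). Dimethylamino and chloro also land level, with a 1.0-fold lower number from compound 2 to compound 4 (0.02 log units; within the scatter), so two different groups reach the same range here, while methoxy stays level with plain hydrogen and goes against any simple rule that a group here lowers the number. The data shown include no separate measurement that could explain these shifts.

On these data alone, it remains open whether a fluoro, a nitrile or a carboxylic acid at this position would join the lower pair or stay level with hydrogen and methoxy. An amino group without its methyls, or with a longer chain on the nitrogen, would test how much of the dimethylamino group this result needs.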